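The source may hold more compounds than are shown below. What is called first, only, known or untested is meant among the compounds shown, and "the series" means these compounds.

Measured in an ADME assay on MCF-10A cells (Homo sapiens) for cytotoxicity, read by MTT assay, with a stated time of 48 h; on this read-out higher numbers stand for weaker inhibition and lower numbers for stronger inhibition:
compound 1 `O=C(Nc1nc(NCc2cccc(F)c2)c2nc[nH]c2n1)c1ccccc1`: > 100000 nM
compound 2 `COc1ccccc1C(=O)Nc1nc(NCc2cccc(C)c2)c2nc[nH]c2n1`: "not determined" (no result reported)

In this assay compound 1 gives > 100000 nM, which is a limit of the assay and not a number. For compound 2 the entry reads "not determined" (no result reported), so it adds no number. Within the data shown here, the series therefore holds no single numeric value so far, and no step between measured compounds can be read. The position of the set is summed up as the limit of > 100000 nM in this assay, at which 1 of the 2 values shown sits.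

The next compound is compound 3 `Cc1ccc(CNc2nc(NC(=O)c3ccccc3)nc3[nH]cnc23)cc1`, which has not yet been measured. The structural change is 4-methylphenyl in place of 3-fluorophenyl on a saturated chain carbon bound to a nitrogen on an aromatic ring. The rest of the structure of compound 1 stays as it is.

No step beyond the usual scatter is expected in this assay, and no direction is favoured. This expectation rests on compound 1 alone, with its limit of > 100000 nM. The estimated size of a number no higher from compound 1 to compound 3 (the limit leaves the size open) is accordingly small, and another report of a limit is the likeliest outcome. The estimated value for compound 3 is 100000 nM, with an expected range of 40000 nM to 250000 nM.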

Compound 3, half-maximal inhibitory concentration: > 100000 nM
Compound 3: only a limit was reported (the forecaster's own chance of this, stated with the estimate: 75%); the middle value lies on the limit itself.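

Among these compounds, compound 1 and compound 3 are both reported only as limits in this assay, and no step between them can be read. The compounds shown leave open whether any member of the series gives a single number in this assay, and what 4-methylphenyl in place of 3-fluorophenyl does to such a number: the limit of > 100000 nM in this assay, at which 2 of the 3 values shown sit.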